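The compounds below may be only part of what the source reports. "The series", "measured", "known", "first", "only" and "open" are said of these compounds alone.

Of the compounds shown here, two that share one core have so far been tested in a functional assay on HUVEC cells (Homo sapiens) for inhibition, tested at 5 ug/mL; a higher number here means a stronger effect of the compound at the concentration tested, a lower number a weaker effect. Compound 1 `COc1cc(/C=C/C(=O)c2cccc(NC(=O)c3cc(Cl)cc(Cl)c3)c2)ccc1O` gives 51% in this assay. Compound 2 `COc1cc(/C=C/C(=O)c2cccc(NC(=O)c3ccco3)c2)ccc1O` gives 82% in this assay, the higher of the two numbers, with compound 1 as the nearest and lower one. Going by the values given here, the single step known in this set is a number 31 percentage points higher from compound 1 to compound 2 (beyond the scatter). Compound 3 `COc1cc(/C=C/C(=O)c2cccc(NC(=O)c3ccc(Cl)cc3Cl)c2)ccc1O` has not yet been measured. It differs from compound 2 in one place: 2,4-dichlorophenyl in place of furan-2-yl on a carbonyl carbon. That one measured step bears directly on the present change, since it removed a dichlorophenyl ring in favour of the furan ring and was large, whereas the new change brings a dichlorophenyl ring back in place of the furan ring. Read in the opposite direction, it points to a loss. Among the compounds with values here, only one such step exists, and the 3,5-dichlorophenyl and 2,4-dichlorophenyl rings are not the same, so the size is uncertain. A drop of roughly the earlier size is expected, a number 27 percentage points lower from compound 2 to compound 3 (beyond the scatter). Compound 3 is therefore estimated to give 55% in this assay, within a range from 35% to 75%.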

Compound 3, a percentage reported as inhibition, at one concentration (the size of the read-out at that concentration, not a potency): 51%
For compound 3 the middle estimate is 4 percentage points above the measured one; low and high end bracket the measured number.
By their numbers in this assay, from the lowest: compounds 1 and 3 (each within the scatter of the next); then compound 2.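

In this assay, the swap of furan-2-yl for a second dichlorophenyl pattern gives a number 31 percentage points lower from compound 2 to compound 3 (beyond the scatter), so the earlier difference between these rings is not confined to the 3,5-dichlorophenyl group. Changing 3,5-dichlorophenyl to 2,4-dichlorophenyl on the same carbonyl carbon gives no change at the digits printed from compound 1 to compound 3 (within the scatter), which means that these two chlorine patterns cannot be told apart here, and across these three compounds the clear divide lies between furan-2-yl and the two dichlorophenyl rings. Nothing available explains why this divide appears.

The compounds shown leave open whether the higher number belongs specifically to furan-2-yl, or whether a phenyl ring without chlorine, a thiophene ring, a pyridine ring or a short alkyl chain on the same carbonyl carbon would read like it. They also leave open whether removing one chlorine, or replacing both chlorines with methyl groups, would keep the number of the dichlorophenyl compounds or move it toward that of the furan-2-yl compound.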